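Notes on the aryl-to-benzyl swap at the ring nitrogen

The source may hold more compounds than are shown below. What is called first, only, known or untested is meant among the compounds shown, and "the series" means these compounds.

compound 1, `Cc1ccc(-n2cc(CNC(=O)c3cccc4c3cnn4C(C)C)nn2)c(C)c1`: in a functional assay on MCF7 cells (Homo sapiens) for inhibition, read by MTT assay, with a stated time of 72 h (a lower number here means a stronger inhibitor, a higher number a weaker inhibitor), compound 1 gives only a limit, > 40000 nM.
compound 2, `CCc1ccc(-n2cc(CNC(=O)c3cccc4c3cnn4C(C)C)nn2)cc1`: in this assay compound 2 gives only a limit, > 40000 nM.
compound 3, `COc1ccc(-n2cc(CNC(=O)c3cccc4c3cnn4C(C)C)nn2)cc1`: in this assay compound 3 gives only a limit, > 40000 nM.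

Compound 3 stands where every value of the series sits, at the limit of > 40000 nM in this assay, at which 3 of the 3 values shown sit. The steps a step that the two limits leave unreadable from compound 1 to compound 3 and a step that the two limits leave unreadable from compound 2 to compound 3 are therefore unreadable, and a step that the two limits leave unreadable from compound 1 to compound 2 likewise. Compound 4 is `CC(C)n1ncc2c(C(=O)NCc3cn(Cc4ccc(C#N)cc4)nn3)cccc21`; it differs from compound 3 by 4-cyanobenzyl in place of 4-methoxyphenyl on an aromatic nitrogen. Going by the values given here, no measured step informs this change, since the ring nitrogen substituents tried so far all leave the series at the limit. Compound 4 is expected to remain near that limit, with a number no higher from compound 3 to compound 4 (the limit leaves the size open) as the estimated step. For compound 4 the estimate in this assay is 40000 nM, within 8000 nM to 200000 nM.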

Compound 4, half-maximal inhibitory concentration: > 40000 nM
Compound 4: no number, only a limit (the forecaster's own chance of this, stated with the estimate: 80%); the middle value lies on the limit itself.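

The steps from compound 1, compound 2 and compound 3 to compound 4 cannot be read, and all four compounds stay at a single limit: the limit of > 40000 nM in this assay, at which 4 of the 4 values shown sit. The compounds shown leave open whether any ring nitrogen substituent gives a measurable number in this assay.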